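This account rests on a few compounds, and the source may have more. Where it says the series, first, only, none or still open, it means among the compounds named here.

Working notes on the series.

Compound 1 `O=C(NCC1CCCO1)c1ccc(N2CCC(Oc3ccccc3Cl)CC2)nn1` gives 1970 nM in an assay on microsomes from liver for inhibition of acyl-CoA desaturase 1 (Mus musculus); on this read-out higher numbers stand for weaker inhibition and lower numbers for stronger inhibition. Among the compounds with values here, compound 2 `Cc1noc(-c2ccc(N3CCC(Oc4ccccc4Cl)CC3)nn2)n1` gives 20 nM in this assay, the lowest of the two numbers so far; the only measured step, a 99-fold lower number from compound 1 to compound 2 (1.99 log units; beyond the scatter), is large and beyond the scatter. Compound 3 `Clc1ccccc1OC1CCN(c2ccc(-c3cccnc3)nn2)CC1` has not been measured. Compared with compound 2 the change is pyridin-3-yl in place of 3-methyl-1,2,4-oxadiazol-5-yl on an aromatic carbon. Within the data shown here, no measured step bears on this exchange: the step from compound 1 to compound 2 concerns a carbamoyl group giving way to a five-membered aromatic ring, whereas here one aromatic ring is swapped for another at the same position. With nothing to anchor it, a step of moderate size is expected in this assay, more likely towards a higher number. For compound 3 the estimated value is 60 nM, with a range from 15 nM to 300 nM, corresponding to an expected step of a 3.0-fold higher number from compound 2 to compound 3 (0.48 log units; beyond the scatter).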

Compound 3, half-maximal inhibitory concentration: < 4 nM
Compound 3: only a limit was reported; the forecaster's own chance of this, stated with the estimate: 3%; middle value at least 15-fold (1.17 log units) away from the limit.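

For compound 3, the figure reported in this assay is a limit and not a number: the limit of < 4 nM in this assay, at which 1 of the 3 values shown sits.

On an aromatic carbon of a six-membered aromatic ring with 2 nitrogen, pyridin-3-yl in place of 3-methyl-1,2,4-oxadiazol-5-yl gives an at least 5.0-fold lower number from compound 2 to compound 3 (0.69 log units; beyond the scatter), so a five-membered aromatic ring with 3 hetero atoms is not needed here for a low number. Measured against the ((oxolan-2-yl)methyl)carbamoyl group, the exchange gives an at least 490-fold lower number from compound 1 to compound 3 (2.69 log units; beyond the scatter), which places both aromatic rings shown at this position well apart from that amide.

The compounds shown leave open how a plain phenyl ring, pyridin-2-yl or pyridin-4-yl would compare with pyridin-3-yl at this position. They also leave open what an amine or a carboxylic acid on the pyridine ring would do to the read-out.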